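Series notes: acid to ethyl at the chain carbon

The compounds below may be only part of what the source reports. "The series", "measured", "known", "first", "only" and "open" are said of these compounds alone.

Measured so far:
compound 1, `CC(=O)N[C@H](C(=O)N1C[C@H](O)C[C@H]1C(=O)N[C@@H](CCc1ccc(Br)cc1)c1ccc(-c2scnc2C)cc1)C(C)(C)C`: 4.08
compound 2, `CC(=O)N[C@H](C(=O)N1C[C@H](O)C[C@H]1C(=O)N[C@@H](CCC(=O)O)c1ccc(-c2scnc2C)cc1)C(C)(C)C`: 1.02

Among the measured compounds shown here, compound 2 stands lowest of the two numbers in a physicochemical assay for lipophilicity, measured as octanol-water partition; on this read-out lower numbers stand for lower lipophilicity and higher numbers for higher lipophilicity; its nearest neighbour is compound 1, and the single measured step, a number 3.06 log units lower from compound 1 to compound 2 (beyond the scatter), is large and beyond the scatter. Compound 3, `CCCC[C@H](NC(=O)[C@@H]1C[C@@H](O)CN1C(=O)[C@@H](NC(C)=O)C(C)(C)C)c1ccc(-c2scnc2C)cc1`, has not been measured. It differs from compound 2 by ethyl in place of carboxy on a saturated chain carbon, three bonds along the chain from an amide-type nitrogen and an aromatic carbon, at the same place where compound 1 and compound 2 differ. For the measured compounds named here, the only step that bears on it is the one from compound 1 to compound 2; it shows that exchanging the group at this chain carbon can shift this assay by a large amount. A move from carboxy to ethyl is expected to run in the opposite direction to that step, upward and beyond the scatter, though ethyl is a smaller group than 4-bromophenyl, so the rise is expected to fall short of the whole of it. The step from compound 2 to compound 3 is estimated at a number 2.28 log units higher from compound 2 to compound 3 (beyond the scatter). For compound 3 the expected value in this assay is 3.3, with a likely range from 2.6 to 4.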

Compound 3, partition coefficient: 2.75
Beside the measured number, compound 3's estimate is 0.55 log units above it; measured number inside the range.
By their numbers in this assay, from the lowest: compound 2; then compound 3; then compound 1.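

In this assay, ethyl in place of carboxy gives a number 1.73 log units higher from compound 2 to compound 3 (beyond the scatter), while ethyl in place of 4-bromophenyl gives a number 1.33 log units lower from compound 1 to compound 3 (beyond the scatter). This chain carbon therefore carries at least three distinct levels among the compounds shown, and compound 3, with a group of no ring and no hydrogen-bond donor or acceptor, stands apart from both compound 1 and compound 2 rather than matching either. No supporting data are available to account for the size of these steps.

Three groups at one position define no trend in this assay, so the effect of chain length or of a ring alone remains unresolved. An amine, a hydroxyl or an unsubstituted phenyl at this chain carbon could show where each would fall within this span.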